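The compounds below may be only part of what the source reports. "The series", "measured", "known", "first", "only" and "open" are said of these compounds alone.

Measured in a functional assay on A-375 cells (Homo sapiens) for antiproliferative activity; on this read-out higher numbers stand for weaker inhibition and lower numbers for stronger inhibition:
- compound 1 `CCCCO/N=C/c1c(N)ncnc1Oc1ccc2[nH]c(C)cc2c1F`: 446 nM
- compound 2 `Cc1cc2c(F)c(Oc3ncnc(N)c3/C=N/OCCO)ccc2[nH]1`: 372 nM
- compound 3 `Cc1cc2c(F)c(Oc3ncnc(N)c3/C=N/O)ccc2[nH]1`: 492 nM

Among the compounds with values here, the three numbers lie close together, and compound 1 stands among them with no step to either neighbour beyond the scatter.

Compound 4 `Cc1cc2c(F)c(Oc3ncnc(N)c3/C=N/OCc3ccccc3)ccc2[nH]1` has not been measured yet. The change that leads to it from compound 1 is phenyl in place of propyl on a saturated chain carbon bound to an oxygen on an unsaturated carbon. In other words, butyl gives way to benzyl.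

Within the data shown here, two measured steps touch this same chain. One shortens it to nothing, a 1.1-fold higher number from compound 1 to compound 3 (0.04 log units; within the scatter). The other ends it in a hydroxy group, a 1.2-fold lower number from compound 1 to compound 2 (0.08 log units; within the scatter). The remaining step, a 1.3-fold higher number from compound 2 to compound 3 (0.12 log units; within the scatter), tells the same story. So in this assay this chain has so far been changed freely with little visible result. None of these compounds carries a ring on the chain, however, so the evidence for compound 4 is indirect.

No shift beyond the scatter is therefore expected, and the expected step is a 1.1-fold lower number from compound 1 to compound 4 (0.05 log units; within the scatter). For compound 4 the estimated value is 400 nM, with an expected range of 170 nM to 950 nM.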

Compound 4, half-maximal inhibitory concentration: 62 nM
Compound 4: middle estimate off by 6.5-fold (0.81 log units), on the high side; measured number outside the range, below it.
By their numbers in this assay, from the lowest: compound 4; then compounds 2, 1 and 3 (each within the scatter of the next).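

In this assay this chain on the oxygen no longer looks indifferent: replacing butyl with benzyl gives a 7.2-fold lower number from compound 1 to compound 4 (0.86 log units; beyond the scatter) and so moves the number beyond the scatter, which no earlier change on this chain had done. The gap is just as clear against the other two compounds, with a 7.9-fold lower number from compound 3 to compound 4 (0.90 log units; beyond the scatter) and a 6.0-fold lower number from compound 2 to compound 4 (0.78 log units; beyond the scatter) so, among these four compounds, the lower number goes with benzyl alone. There is no measurement here that explains the difference.

Still open, as far as these compounds go, is whether an aromatic ring is needed at all, or whether a saturated ring such as cyclohexylmethyl or a longer plain chain such as hexyl would do the same. Also open, from the compounds shown here alone, is how the number would respond to phenethyl, or to a benzyl ring carrying a chloro or methoxy group.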